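The source may hold more compounds than are shown below. What is called first, only, known or untested is meant among the compounds shown, and "the series" means these compounds.

The series rests on two measured compounds. Compound 1 `Clc1ccc(-c2cc(-c3ccsc3)nc(-c3ccco3)c2)o1` in a functional assay on K562 cells (Homo sapiens) for cytotoxicity, in the presence of a further agent that is not named here (on this read-out higher numbers stand for weaker inhibition and lower numbers for stronger inhibition), gives 22400 nM. Compound 2 `Clc1ccc(-c2cc(-c3cccnc3)nc(-c3cccs3)c2)o1` in this assay gives 22300 nM, the lower of the two numbers shown, though the gap to compound 1 lies within the scatter of repeated measurements, so the two cannot be told apart on this evidence.

Compound 3 `Clc1ccc(-c2cc(-c3ccco3)nc(-c3cccs3)c2)o1` has not yet been measured. It differs from compound 2 in one place: furan-2-yl in place of pyridin-3-yl on an aromatic carbon. Among the measured compounds shown here, no step between measured compounds shows what this particular exchange does. For the measured compounds named here, the only guide is that compound 1, which already carries a furan-2-yl group on the shared core, and compound 2 sit at the same level in this assay.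

On that basis compound 3 is expected to stay close to compound 2, with no step beyond the scatter; the step from compound 2 to compound 3 is estimated as a 1.0-fold lower number from compound 2 to compound 3 (0.01 log units; within the scatter). Compound 3 is accordingly expected to give about 22000 nM in this assay, with a range from 8000 nM to 60000 nM.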

Compound 3, half-maximal inhibitory concentration: 16000 nM
Beside the measured number, compound 3's estimate is 1.4-fold (0.14 log units) above it, and the stated range covers the measured number.
By their numbers in this assay, from the lowest: compounds 3, 2 and 1 (each within the scatter of the next).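

Furan-2-yl in place of pyridin-3-yl, on the aromatic carbon next to the ring nitrogen, gives the first direct reading of an exchange between measured compounds in this assay (a 1.4-fold lower number from compound 2 to compound 3 (0.14 log units; within the scatter)), and the step lies within the scatter, so a five-membered and a six-membered aromatic ring, each with 1 hetero atom, cannot be told apart here. Thiophen-2-yl in place of thiophen-3-yl likewise stays within the scatter (a 1.4-fold lower number from compound 1 to compound 3 (0.15 log units; within the scatter)), so the three compounds sit at one level in this read-out, and neither exchange among these aromatic rings separates them. Nothing measured here offers an explanation for either step.

The compounds shown leave open whether any group at this position would move the number beyond the scatter, as all three carry only an aromatic ring with 1 hetero atom there. As far as these compounds go, an amine such as piperidin-1-yl, a carboxylic acid or a longer alkyl chain on the same aromatic carbon would test this, and the effect of exchanging the 5-chlorofuran-2-yl group also remains unknown.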